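Methoxy for methyl in the propyl compound

This account rests on a few compounds, and the source may have more. Where it says the series, first, only, none or still open, it means among the compounds named here.

Values in a functional assay on MCF7 cells (Homo sapiens) for antiproliferative activity, read by sulforhodamine B assay, with a stated time of 48 h; on this read-out higher numbers stand for weaker inhibition and lower numbers for stronger inhibition:
compound 1 `Cc1ccccc1OS(=O)(=O)c1ccc(N2CCN(C)C2=O)cc1`: 5600 nM
compound 2 `CCN1CCN(c2ccc(S(=O)(=O)Oc3ccccc3OC)cc2)C1=O`: > 100000 nM (a limit)
compound 3 `CCCN1CCN(c2ccc(S(=O)(=O)Oc3ccccc3C)cc2)C1=O`: > 100000 nM (a limit)
compound 4 `CCCN1CCN(c2ccc(S(=O)(=O)Oc3ccccc3OC)cc2)C1=O`: not yet measured

Compound 3 gives > 100000 nM, a limit and not a number. It stands at the limit of > 100000 nM in this assay, at which 2 of the 3 values shown sit, and has no measured number of its own.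

Compound 4 carries methoxy in place of methyl on an aromatic carbon and keeps the propyl chain of compound 3. For the measured compounds named here, no measured pair isolates this change. Going by the values given here, the only measured step, an at least 17-fold higher number from compound 1 to compound 3 (1.25 log units; beyond the scatter), is large, but it concerns the chain and not this aromatic carbon. Compound 2 also carries methoxy, with an ethyl chain, and gives > 100000 nM, again a limit.

In this assay no step beyond the scatter is expected, and a reading at the limit is likely for compound 4. The estimated step is a number no higher from compound 3 to compound 4 (the limit leaves the size open). For compound 4 the expected value is 100000 nM, with an estimated range from 40000 nM to 200000 nM.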

Compound 4, half-maximal inhibitory concentration: 13000 nM
Beside the measured number, compound 4's estimate is 7.7-fold (0.89 log units) above it; measured number outside the range, below it.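

In this assay this aromatic carbon, ortho to a large group, proves sensitive: with the propyl chain held constant, methoxy in place of methyl gives an at least 7.6-fold lower number from compound 3 to compound 4 (0.88 log units; beyond the scatter) and restores a measured number to the propyl series. The chain matters too, since among the methoxy compounds the added methyl on the chain gives an at least 7.6-fold lower number from compound 2 to compound 4 (0.88 log units; beyond the scatter) while the chain change among the methyl compounds gives an at least 17-fold higher number from compound 1 to compound 3 (1.25 log units; beyond the scatter) and so runs the other way. Chain growth therefore has no single direction in these compounds, and its outcome depends on the group at the aromatic carbon.

From the compounds shown here alone, whether ethoxy or chlorine at this aromatic carbon, or a butyl chain with methoxy retained, would extend the gain remains open. Compound 2 and compound 3 each stand at a limit and not at a number, so the full size of both new steps also stays open: the limit of > 100000 nM in this assay, at which 2 of the 4 values shown sit.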